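A few compounds are considered here, and "the series" means these few. Any claim that something is new, unique, unknown or untested is made for them only; others in the source may bear on it.

Compounds measured so far:
- compound 1 `COc1c(Br)cccc1C(=O)Nc1ccc(Sc2nc3ccccc3s2)c(Cl)c1` — > 100000 nM, a limit of the assay
- compound 2 `O=C(Nc1ccc(Sc2nc3ccccc3s2)c(Cl)c1)c1cccc(Br)c1O` — 6900 nM
- compound 3 `O=C(Nc1ccc(Sc2nc3ccccc3s2)c(Cl)c1)c1ccccc1` — > 100000 nM, a limit of the assay

In an assay for inhibition of HSP60/HSP10 (Homo sapiens), with a stated time of 60 min (a higher number here means a weaker inhibitor, a lower number a stronger inhibitor), compound 1 gives > 100000 nM, which is a limit and not a number. Compound 2 gives 6900 nM; the step is an at least 14-fold lower number from compound 1 to compound 2 (1.16 log units; beyond the scatter). Compound 3 gives > 100000 nM, again a limit. Between them stands an at least 14-fold higher number from compound 2 to compound 3 (1.16 log units; beyond the scatter), while the step from compound 1 to compound 3 is a step that the two limits leave unreadable from compound 1 to compound 3. Compound 1 thus stands at the weak end of what is shown, at the limit of > 100000 nM in this assay, at which 2 of the 3 values shown sit.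

Compound 4 `COc1c(Br)cccc1C(=O)Nc1ccc(Sc2nc3ccccc3s2)cc1` differs from compound 1 as hydrogen in place of chloro on an aromatic carbon. Among the measured compounds shown here, none of the measured steps touches the chloro; all three alter the aromatic group on the carbonyl carbon. For the measured compounds named here, there is therefore no measured step that bears on this change, and no step beyond the scatter is expected in this assay. Since compound 1 already sits at the limit, compound 4 is expected near that limit, with a step that the limit leaves unreadable from compound 1 to compound 4 as the expected step. The estimate for compound 4 is 150000 nM, within 40000 nM to 600000 nM.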

Compound 4, half-maximal inhibitory concentration: > 100000 nM
Compound 4: only a limit was reported (the forecaster's own chance of this, stated with the estimate: 85%); the middle value lies beyond the limit too.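

In this assay compound 4 gives > 100000 nM, a limit of the assay. Compound 1 also stands at a limit, so no step can be read between compound 1 and compound 4. The compounds shown leave open what hydrogen in place of chloro does where the starting value is a number, as in compound 2.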